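The source may hold more compounds than are shown below. What is called first, only, known or untested is meant among the compounds shown, and "the series" means these compounds.

In a functional assay on MCF7 cells (Homo sapiens) for inhibition, with a stated time of 96 h (a higher number here means a weaker inhibitor, a lower number a stronger inhibitor), two compounds of this series have been measured so far. Compound 1 (`COc1cc(C(=O)c2cn(-c3ccc(F)cc3)cc2-c2ncco2)cc(OC)c1OC`) gives 93 nM in this test, and compound 2 (`COc1cc(C(=O)c2cn(-c3ccc(C)cc3)cc2-c2ccccn2)cc(OC)c1OC`) gives 36 nM in the same test. Compound 2 therefore holds the lower of the two numbers, and its gap to compound 1 lies beyond the scatter, which makes compound 2 the stronger inhibitor of the pair. These two compounds differ in more than one place, so the gap cannot be assigned to any single group.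

Compound 3 (`COc1cc(C(=O)c2cn(-c3ccc(F)cc3)cc2-c2ccccn2)cc(OC)c1OC`) departs from compound 2 in one place only (fluoro in place of methyl on an aromatic carbon). The change turns 4-methylphenyl into 4-fluorophenyl. Among the measured compounds shown here, no measured pair isolates this exchange, so the data give no direct guide to it. A small weakening in this assay is expected, probably not beyond the scatter. The expected change is a 1.4-fold higher number from compound 2 to compound 3 (0.14 log units; within the scatter) as estimated here. The estimate for compound 3 is 50 nM with an expected range of 20 nM to 125 nM as its bounds.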

Compound 3, half-maximal inhibitory concentration: 73 nM
Beside the measured number, compound 3's estimate is 1.5-fold (0.16 log units) below it; the measured number falls inside the stated range.
By their numbers in this assay, from the lowest: compound 2; then compounds 3 and 1 (each within the scatter of the next).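

Within this assay, the exchange of methyl for fluoro on an aromatic carbon, para to a large group, now has a direct reading: it gives a 2.0-fold higher number from compound 2 to compound 3 (0.31 log units; beyond the scatter), a modest step that lies just beyond the scatter. This place on the ring therefore responds to the exchange, and of the two groups seen here with pyridin-2-yl in the molecule, 4-methylphenyl goes with the stronger inhibition. With 4-fluorophenyl held constant, pyridin-2-yl in place of 1,3-oxazol-2-yl gives a 1.3-fold lower number from compound 1 to compound 3 (0.11 log units; within the scatter), which is within the scatter, so this assay does not tell those two groups apart, and the gap first seen between the two earlier compounds can be read as following the methyl to fluoro exchange rather than this one. Nothing available here accounts for the size of either step.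

The compounds shown leave open how a chloro group, a methoxy group or an amine at this same place would compare with methyl and fluoro. They also leave open whether the methyl to fluoro step keeps its size when 1,3-oxazol-2-yl takes the place of pyridin-2-yl.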